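This account rests on a few compounds, and the source may have more. Where it says the series, first, only, none or still open, it means among the compounds named here.

In an assay on LM cells for displacement of a labelled ligand from Neuropeptide Y receptor type 5 (Homo sapiens) (a higher number here means a weaker inhibitor, a lower number a stronger inhibitor), compound 1 `Fc1ccc(C2(c3ccc(F)cc3)CNC(c3cccc(Br)c3)=N2)cc1` gives 4.8 nM, the lowest of the three numbers measured here. Compound 2 `Fc1ccc(C2(c3ccc(F)cc3)CNC(c3cccc(F)c3)=N2)cc1` gives 10 nM, and compound 3 `CC(=O)c1cccc(C2=NC(c3ccc(F)cc3)(c3ccc(F)cc3)CN2)c1` gives 44 nM. Both measured changes touch the same group that carries the bromo atom in compound 1: a 2.1-fold higher number from compound 1 to compound 2 (0.32 log units; beyond the scatter), and a 9.2-fold higher number from compound 1 to compound 3 (0.96 log units; beyond the scatter). Compound 4 `Fc1ccc(C2(c3ccc(F)cc3)CNC(c3ccncc3)=N2)cc1` has not yet been measured; it differs from compound 1 by pyridin-4-yl in place of 3-bromophenyl on a carbon with a double bond to nitrogen. For the measured compounds named here, no measured step exchanges this whole group, yet both steps that alter it gave higher numbers, so a modest rise is expected for compound 4: a 6.3-fold higher number from compound 1 to compound 4 (0.80 log units; beyond the scatter). Compound 4 is therefore estimated at 30 nM, with an expected range from 8 nM to 120 nM.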

Compound 4, half-maximal inhibitory concentration: 160 nM
For compound 4 the middle estimate is 5.3-fold (0.73 log units) below the measured one, outside the stated range (above it).
By their numbers in this assay, from the lowest: compound 1; then compound 2; then compound 3; then compound 4.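

Replacing the whole ring on this carbon costs more than any of the substituent swaps on the phenyl ring, with a 33-fold higher number from compound 1 to compound 4 (1.52 log units; beyond the scatter) and a 16-fold higher number from compound 2 to compound 4 (1.20 log units; beyond the scatter) as the two large steps. Even the acetyl compound keeps an edge, with a 3.6-fold higher number from compound 3 to compound 4 (0.56 log units; beyond the scatter) as a modest step, so all three substituted phenyl rings give lower numbers than pyridin-4-yl. Nothing available explains this loss.

Still open, going by these compounds, is how a plain phenyl ring would compare, which would separate the effect of the ring nitrogen from that of losing the substituent. Also open, on these data alone, is how an amine or a carboxylic acid on that phenyl ring would behave.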